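A few compounds are considered here, and "the series" means these few. Any claim that something is new, unique, unknown or untested is made for them only; others in the source may bear on it.

Measured in an ADME assay on HEK293 cells (Homo sapiens) for cytotoxicity, read by MTT assay, with a stated time of 72 h; on this read-out higher numbers stand for weaker inhibition and lower numbers for stronger inhibition:
Compound 1 `O=C(CN1CCN(C(=O)c2ccc(Cl)cc2)CC1)N1CCN(CCCc2c[nH]c3ccccc23)CC1` gives 98200 nM
Compound 2 `O=C(CN1CCN(C(=O)c2ccc(Cl)cc2)CC1)N1CCN(CCCc2c[nH]c3ccc(F)cc23)CC1` gives 44500 nM
Compound 3 `COc1ccc2[nH]cc(CCCN3CCN(C(=O)CN4CCN(C(=O)c5ccc(Cl)cc5)CC4)CC3)c2c1` gives 117000 nM

Compound 3 stands level with compound 1 within the scatter (a 1.2-fold higher number from compound 1 to compound 3 (0.08 log units; within the scatter)) and clearly apart from compound 2 (a 2.6-fold higher number from compound 2 to compound 3 (0.42 log units; beyond the scatter)). Compound 4 `COc1ccc2[nH]cc(CCCN3CCN(C(=O)CN4CCN(C(=O)c5cccc(Cl)c5)CC4)CC3)c2c1` keeps all of compound 3 except for one group: it has 3-chlorophenyl in place of 4-chlorophenyl on a carbonyl carbon. Within the data shown here, no measured step touches this group, so the evidence is indirect. The available steps swap a different substituent elsewhere in the molecule, fluoro for hydrogen (a 2.2-fold lower number from compound 1 to compound 2 (0.34 log units; beyond the scatter)) and methoxy for hydrogen (a 1.2-fold higher number from compound 1 to compound 3 (0.08 log units; within the scatter)). Even these additions of new groups gave a modest step at most. The present change adds and removes no atoms, so no step beyond the scatter is expected in this assay in either direction. The expected step is small (a 1.1-fold lower number from compound 3 to compound 4 (0.05 log units; within the scatter)). Compound 4 is estimated at 105000 nM (expected range 55000 nM to 190000 nM).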

Compound 4, half-maximal inhibitory concentration: 143000 nM
Compound 4: the middle estimate sits 1.4-fold (0.13 log units) below what was measured; measured number inside the range.
By their numbers in this assay, from the lowest: compound 2; then compounds 1, 3 and 4 (each within the scatter of the next).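

In this assay, placing 3-chlorophenyl instead of 4-chlorophenyl on the carbonyl carbon gives a 1.2-fold higher number from compound 3 to compound 4 (0.09 log units; within the scatter), the only step shown that touches this group. Among these compounds, with the methoxy compounds, the two chlorophenyl groups therefore cannot be told apart in this cytotoxicity read-out, even though the earlier steps changed only the other end of the molecule. No measurement here bears on the reason for this result.

Going by these compounds, this single pair carries the methoxy group, so it remains open whether the same swap would also stay within the scatter on the compound with fluoro or on the one with hydrogen at that place. On these data alone, it is also open how this assay would respond if a plain phenyl or a pyridine ring sat on the same carbonyl carbon.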